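Methoxy to Trifluoromethyl in a Series Stuck at the Limit

The source may hold more compounds than are shown below. What is called first, only, known or untested is meant among the compounds shown, and "the series" means these compounds.

Compound 1, `OC[C@H]1O[C@@H](n2cnc3c(NCc4cccc(Br)c4)ncnc32)[C@H](O)[C@@H]1O`: only a limit, > 166000 nM
Compound 2, `COc1ccccc1CNc1ncnc2c1ncn2[C@@H]1O[C@H](CO)[C@@H](O)[C@H]1O`: only a limit, > 166000 nM
Compound 3, `COc1cccc(CNc2ncnc3c2ncn3[C@@H]2O[C@H](CO)[C@@H](O)[C@H]2O)c1`: only a limit, > 166000 nM

In a functional assay on MCF cells (Homo sapiens) for antiproliferative activity, with a stated time of 72 h (on this read-out lower numbers stand for stronger inhibition and higher numbers for weaker inhibition), none of the three measured compounds gives a real number. Compound 3 sits at the limit of > 166000 nM in this assay, at which 3 of the 3 values shown sit, and that is all that is known of it. Every value is a limit. The steps a step that the two limits leave unreadable from compound 1 to compound 2, a step that the two limits leave unreadable from compound 1 to compound 3 and a step that the two limits leave unreadable from compound 2 to compound 3 cannot be read, so nothing separates these three compounds from one another in this assay.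

Compound 4, `OC[C@H]1O[C@@H](n2cnc3c(NCc4cccc(C(F)(F)F)c4)ncnc32)[C@H](O)[C@@H]1O`, differs from compound 3 by trifluoromethyl in place of methoxy on an aromatic carbon. Within the data shown here, no measured step covers this exchange, and the steps that do exist are all unreadable, so there is no ground to expect compound 4 to break away from the pattern of limits. The step that the limit leaves unreadable from compound 3 to compound 4 is therefore expected to be essentially nothing. Compound 4 is estimated to reach about 200000 nM in this assay, within a range of 40000 nM to 1000000 nM, most likely reported again only as a limit.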

Compound 4, half-maximal inhibitory concentration: > 166000 nM
Compound 4: no number, only a limit (the forecaster's own chance of this, stated with the estimate: 80%); the middle value is on the limit's open side.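

In this assay, among these compounds, compound 4 gives > 166000 nM, again only a limit, so no step from compound 1, compound 2 or compound 3 to compound 4 can be read. Going by these compounds, whether any of these four compounds differs from the others remains open, since all share one limit: the limit of > 166000 nM in this assay, at which 4 of the 4 values shown sit.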